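This account rests on a few compounds, and the source may have more. Where it says the series, first, only, none or still open, it means among the compounds named here.

In a functional assay on K562 cells (Homo sapiens) for antiproliferative activity, read by sulforhodamine B assay, with a stated time of 72 h (a lower number here means a stronger inhibitor, a higher number a weaker inhibitor), compound 1 `O=C1CS/C(=N/Nc2nncc3ccccc23)N1c1ccccc1` gives 57 nM and compound 2 `COc1ccc(NC(=S)NNc2nncc3ccccc23)cc1` gives 94 nM. Compound 3 `Fc1ccc(Nc2nncc3ccccc23)cc1` gives 6.7 nM, the lowest of the three numbers, and its gaps to both others lie beyond the scatter. Compound 4 `N#Cc1ccc(Nc2nncc3ccccc23)cc1` is still unmeasured. It differs from compound 3 by cyano in place of fluoro on an aromatic carbon. Within the data shown here, no measured pair isolates a single change, so the expectation is loose. A modest rise in the number, perhaps not beyond the scatter, is expected, since compound 3 at 6.7 nM already sits lowest. The expected size is a 2.2-fold higher number from compound 3 to compound 4 (0.35 log units; beyond the scatter). For compound 4 the estimated value is 15 nM, within an expected range of 3 nM to 80 nM.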

Compound 4, half-maximal inhibitory concentration: 2.6 nM
For compound 4 the middle estimate is 5.8-fold (0.76 log units) above the measured one; measured number below the stated range.
By their numbers in this assay, from the lowest: compound 4; then compound 3; then compounds 1 and 2 (each within the scatter of the next).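

Cyano in place of fluoro gives a 2.6-fold lower number from compound 3 to compound 4 (0.41 log units; beyond the scatter) in this assay at this aromatic carbon para to a large group, the first single-place step in the series. Among these compounds, the position takes cyano, with two heavy atoms and a hydrogen-bond acceptor, without any loss, and the number falls further below the lowest value so far. Nothing measured here explains the gain.

From the compounds shown here alone, whether an amine or a carboxylic acid at this position would hold the number down remains open. Also open, going by these compounds, is whether an unsubstituted ring would do as well.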